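The source may report more compounds than this note shows. Statements on the series, on what has been measured and on what is new or still open speak of the compounds shown alone.

Working notes on the series.

Compound 1 `Brc1ccc(CSc2nnc(-c3ccncc3)n2-c2ccccc2)cc1` gives 12600 nM in a functional assay on MCF7 cells (Homo sapiens) for inhibition, read by MTT assay, with a stated time of 48 h; a higher number here means a weaker inhibitor, a lower number a stronger inhibitor. Compound 2 `O=[N+]([O-])c1ccccc1CSc1nnc(-c2ccncc2)n1-c1ccccc1` gives only a limit in this assay, > 50000 nM. Among the measured compounds shown here, the step of an at least 3.9-fold higher number from compound 1 to compound 2 (0.59 log units; beyond the scatter) is the sole measured change so far, and the limit of > 50000 nM in this assay, at which 1 of the 3 values shown sits, sets how far it can be read.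

Compound 3 `O=C(CSc1nnc(-c2ccncc2)n1-c1ccccc1)N/N=C/c1ccccc1` gives 23600 nM in this assay. Of the two numbers shown, compound 3 and compound 1 fall within the scatter of each other, so neither is separated from the other.

Compound 4 `O=C(CSc1nnc(-c2ccncc2)n1-c1ccccc1)N/N=C/c1cccc(F)c1` is yet to be measured. It differs from compound 3 by fluoro in place of hydrogen on an aromatic carbon. For the measured compounds named here, the only measured step exchanges one whole ring for another on the saturated chain carbon bound to sulfur, so no measured step bears on adding a fluoro to the ring at the far end of the hydrazone. With nothing to draw on, the expected step of no change at the digits printed from compound 3 to compound 4 (within the scatter) in this assay is none beyond the scatter. Compound 4 is therefore estimated at 23600 nM in this assay, within 9000 nM to 60000 nM.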

Compound 4, half-maximal inhibitory concentration: > 50000 nM
Compound 4 ended at the assay's limit; the forecaster's own chance of this, stated with the estimate: 20%; at least 2.1-fold (0.32 log units) between middle value and limit.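

In this assay, fluoro in place of hydrogen on the ring at the far end of the hydrazone gives an at least 2.1-fold higher number from compound 3 to compound 4 (0.32 log units; beyond the scatter). The earlier step exchanged one whole ring for another on the saturated chain carbon bound to sulfur, whereas here, in the change from phenyl to 3-fluorophenyl, a single heavy atom is enough for a step beyond the scatter. Compound 4 stands at a limit of the assay, so the full size of this step cannot be read: the limit of > 50000 nM in this assay, at which 2 of the 4 values shown sit.

Open, going by these compounds, is whether a methoxy or an amine at the same place on this ring would give a similar step, and so whether the step belongs to fluoro itself or to the place it occupies. Also open, on these data alone, is whether the same change would read alike on the phenyl ring bound directly to the shared core.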